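Extending the amide-nitrogen methyl to ethyl: compound 4

The source may hold more compounds than are shown below. What is called first, only, known or untested is meant among the compounds shown, and "the series" means these compounds.

For the measured compounds named here, compound 2 `CN1CCN(c2ccc(Nc3ncc4c(n3)N(C3CCCC3)CC(=O)N4C)nc2)CC1` holds the only number in the set: in a functional assay on MDA-MB-231 cells (Homo sapiens) for inhibition, read by MTT assay, with a stated time of 48 h (on this read-out higher numbers stand for weaker inhibition and lower numbers for stronger inhibition), compound 2 gives 23700 nM. Compound 1 `CN1CCN(c2ccc(Nc3ncc4c(n3)N(C3CCCC3)CC(=O)N4)nc2)CC1`, bearing hydrogen on the amide-type nitrogen in the ring, reaches only a limit in this assay, namely > 30000 nM. Compound 3 `CC1CCN(c2ccc(Nc3ncc4c(n3)N(C3CCCC3)CC(=O)N4C)nc2)CC1` likewise stops at a limit in this assay, namely > 30000 nM. The steps of an at least 1.2-fold lower number from compound 1 to compound 2 (0.10 log units; that floor lies within the scatter) and an at least 1.2-fold higher number from compound 2 to compound 3 (0.10 log units; that floor lies within the scatter) are both floors fixed by the limit of > 30000 nM in this assay, at which 2 of the 3 values shown sit, and neither floor lies beyond the scatter.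

Compound 4 `CCN1C(=O)CN(C2CCCC2)c2nc(Nc3ccc(N4CCN(C)CC4)cn3)ncc21` differs from compound 2 by methyl in place of hydrogen on a saturated chain carbon bound to an amide-type nitrogen in a ring. Going by the values given here, the nearest precedent is an at least 1.2-fold lower number from compound 1 to compound 2 (0.10 log units; that floor lies within the scatter), the addition of the methyl itself, a shift too small to separate from the scatter. Among the compounds with values here, no measured compound carries anything further out on that nitrogen, so the step to compound 4 is expected to stay within the scatter: a 1.1-fold lower number from compound 2 to compound 4 (0.03 log units; within the scatter). Compound 4 is therefore estimated at 22000 nM in this assay, with a range from 8000 nM to 50000 nM, and a real chance that only a limit is returned.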

Compound 4, half-maximal inhibitory concentration: 24100 nM
For compound 4 the middle estimate is 1.1-fold (0.04 log units) below the measured one; measured number inside the range.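

This position now has its first step with numbers at both ends: in this assay, methyl to ethyl on the amide-type nitrogen in the ring gives a 1.0-fold higher number from compound 2 to compound 4 (0.01 log units; within the scatter). Compound 2 and compound 4 cannot be told apart here, so ethyl serves as well as methyl on this nitrogen, at least within the two compounds shown. Hydrogen to ethyl on the same nitrogen gives an at least 1.2-fold lower number from compound 1 to compound 4 (0.09 log units; that floor lies within the scatter), and the size of that step remains a floor set by the assay limit: the limit of > 30000 nM in this assay, at which 2 of the 4 values shown sit.

The compounds shown leave open whether a longer chain such as propyl, or an amine or a carboxylic acid carried on this nitrogen, would move the number beyond the scatter. On these data alone, the actual number for compound 1, which stands only at a limit, also stays unknown.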